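This account rests on a few compounds, and the source may have more. Where it says the series, first, only, none or still open, it means among the compounds named here.

In a functional assay on Bel-7402 cells (Homo sapiens) for antiproliferative activity, read by MTT assay, with a stated time of 72 h (on this read-out higher numbers stand for weaker inhibition and lower numbers for stronger inhibition), compound 3 (`C=C1C(=O)O[C@H]2[C@H]1CC/C(COC(=O)Cn1cc(F)c(=O)n(Cc3ccc([N+](=O)[O-])cc3)c1=O)=C\CC[C@@]1(C)O[C@@H]21`) gives 4070 nM and compound 2 (`C=C1C(=O)O[C@H]2[C@H]1CC/C(Cn1cc(Cn3cc(F)c(=O)n(Cc4ccc(F)cc4)c3=O)nn1)=C\CC[C@@]1(C)O[C@@H]21`) gives 4910 nM, two values within the scatter of each other. Compound 1 (`C=C1C(=O)O[C@H]2[C@H]1CC/C(Cn1cc(Cn3cc(F)c(=O)[nH]c3=O)nn1)=C\CC[C@@]1(C)O[C@@H]21`) reads > 20000 nM, which is a limit of this assay and not a number.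

The next structure is compound 4 (`C=C1C(=O)O[C@H]2[C@H]1CC/C(COC(=O)Cn1cc(F)c(=O)n(C)c1=O)=C\CC[C@@]1(C)O[C@@H]21`). The change is hydrogen in place of 4-nitrophenyl on a saturated chain carbon bound to an aromatic nitrogen, which also reads as 4-nitrobenzyl to methyl.

Going by the values given here, one measured step bears on this, an at least 4.0-fold lower number from compound 1 to compound 2 (0.60 log units; beyond the scatter), where 4-fluorobenzyl replaced hydrogen on an aromatic nitrogen. Its size is open-ended, as it rests on (the limit of > 20000 nM in this assay, at which 1 of the 3 values shown sits). That step also differs from the present one in the link to the shared core and in leaving no methyl. Read in reverse, it points to a higher number in this assay, beyond the scatter but with a size that is uncertain.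

The estimated change is a 2.7-fold higher number from compound 3 to compound 4 (0.43 log units; beyond the scatter). The expected value for compound 4 is 11000 nM, with an estimated range of 4500 nM to 25000 nM.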

Compound 4, half-maximal inhibitory concentration: 9400 nM
For compound 4 the middle estimate is 1.2-fold (0.07 log units) above the measured one, and the stated range covers the measured number.
By their numbers in this assay, from the lowest: compounds 3, 2 and 4 (each within the scatter of the next, the first and the last beyond it). At a limit, above all of these: compound 1.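

In this assay, going by these compounds alone, the change to methyl gives a 2.3-fold higher number from compound 3 to compound 4 (0.36 log units; beyond the scatter), the first step on this substituent with a number at both ends. With hydrogen in place of 4-nitrophenyl, compound 4 still gives 9400 nM, so a value within the range of this assay does not depend on the 4-nitrophenyl group in this ester series. The earlier step on an aromatic nitrogen gives no size to set beside this one, as the reading for compound 1 is a limit and not a number: the limit of > 20000 nM in this assay, at which 1 of the 4 values shown sits.

The compounds shown do not separate the nitro group from the benzyl ring, so how an unsubstituted benzyl, a 4-aminobenzyl or a propyl chain would read at this place remains open. On these data alone, the effect of the link to the shared core, taken alone, also remains open, as compound 2 and compound 3 differ in more than one place.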